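The compounds below may be only part of what the source reports. "The series", "measured", "known", "first", "only" and "open" are said of these compounds alone.

Compound 2 `C=CC(C)(C)c1[nH]c2ccc(C[C@@H](O)C(C)(C)O)cc2c1/C=C1\NC(=O)[C@H](C)NC1=O` is measured in a functional assay (on this read-out lower numbers stand for stronger inhibition and higher numbers for weaker inhibition), at 79000 nM, level with compound 1 `C=CC(C)(C)c1[nH]c2ccc(CC(=O)C(C)C)cc2c1/C=C1\NC(=O)[C@H](C)NC1=O`, which in this assay gives 79000 nM. Within the data shown here, the one step recorded so far, no change at the digits printed from compound 1 to compound 2 (within the scatter), shows that replacing the group on the saturated chain carbon left the read-out unmoved. Compound 3 `C=CC(C)(C)c1[nH]c2ccccc2c1/C=C1\NC(=O)[C@H](C)NC1=O` differs from compound 2 by hydrogen in place of 2,3-dihydroxy-3-methylbutyl on an aromatic carbon. The earlier swap of one chain for another bears on this removal only loosely, so a step of similar size, within the scatter, is expected, no change at the digits printed from compound 2 to compound 3 (within the scatter). Compound 3 is therefore estimated at 79000 nM, between 25000 nM and 250000 nM.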

Compound 3, half-maximal inhibitory concentration: 103000 nM
Estimate against measurement, compound 3: 1.3-fold (0.12 log units) below; the measured number falls inside the stated range.
By their numbers in this assay, from the lowest: compounds 1, 2 and 3 (each within the scatter of the next).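

In this assay, removing the 2,3-dihydroxy-3-methylbutyl chain from the aromatic carbon gives a 1.3-fold higher number from compound 2 to compound 3 (0.12 log units; within the scatter) and removing the (isopropylcarbonyl)methyl chain gives a 1.3-fold higher number from compound 1 to compound 3 (0.12 log units; within the scatter). Where compounds 1 and 2 compared only one chain with another, these steps compare each chain with hydrogen, and at this position neither chain can be told apart from hydrogen on this read-out. No measurement here bears on this result. As far as these compounds go, whether an amine or a carboxylic acid on this aromatic carbon would move the read-out remains open.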